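The source may hold more compounds than are shown below. What is called first, only, known or untested is meant among the compounds shown, and "the series" means these compounds.

In a functional assay on cells (T-cell line, Homo sapiens) for inhibition (on this read-out lower numbers stand for stronger inhibition and higher numbers for weaker inhibition), compound 1 `COc1ccc(CCCN2CCC(COCC3CCCCC3)CC2)cc1` gives 3000 nM and compound 3 `Clc1ccc(CCCN2CCC(COC(c3ccccc3)c3ccccc3)CC2)cc1Cl` gives 2200 nM, two values within the scatter of each other. Compound 2 `CN1CCC(COC(c2ccccc2)c2ccccc2)CC1` is reported only as a limit, > 20000 nM.

Compound 4 `CCCCCCCCCN1CCC(COC(c2ccccc2)c2ccccc2)CC1` shares its core with compound 3 but carries hexyl in place of 3,4-dichlorophenyl on a saturated chain carbon, three bonds along the chain from an amine nitrogen in a ring.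

Within the data shown here, only one measured step bears on this change. It is an at least 9.0-fold lower number from compound 2 to compound 3 (0.95 log units; beyond the scatter), where 2-(3,4-dichlorophenyl)ethyl replaces hydrogen on a saturated chain carbon bound to an amine nitrogen in a ring. That step lies beyond the scatter, but it adds a group, whereas compound 4 keeps a chain at that place and loses only the ring. Among the measured compounds shown here, no measured step exchanges the aromatic ring for an open chain, so the reading from compound 3 at 2200 nM remains the best guide, and no shift beyond the scatter is expected in this assay. The expected step is a 1.1-fold lower number from compound 3 to compound 4 (0.04 log units; within the scatter). For compound 4 the estimated value is 2000 nM, with an expected range of 600 nM to 6500 nM.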

Compound 4, half-maximal inhibitory concentration: 700 nM
Compound 4: the middle estimate sits 2.9-fold (0.46 log units) above what was measured, within the range that was stated.
By their numbers in this assay, from the lowest: compound 4; then compounds 3 and 1 (each within the scatter of the next). At a limit, above all of these: compound 2.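

In this assay, hexyl in place of 3,4-dichlorophenyl gives a 3.1-fold lower number from compound 3 to compound 4 (0.50 log units; beyond the scatter). At this place, three bonds along the chain from an amine nitrogen in a ring, an aromatic ring is therefore not needed for the lower number, and an open chain of carbon alone goes further than the ring did. Octyl in place of hydrogen on the saturated chain carbon bound to that nitrogen gives an at least 28-fold lower number from compound 2 to compound 4 (1.45 log units; beyond the scatter), a step that marks only a minimum size, as its starting value is a limit: the limit of > 20000 nM in this assay, at which 1 of the 4 values shown sits.

The compounds shown leave open whether the step comes from losing the ring or from losing its two chlorines, which a plain phenyl would separate. They also leave open how a shorter or longer chain, or one ending in a hydroxyl or an amine, would read here.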